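Hydroxylated branched side chain on the xanthine-type core

A few compounds are considered here, and "the series" means these few. Any claim that something is new, unique, unknown or untested is made for them only; others in the source may bear on it.

Working notes on the series. In an assay on cell membranes for binding affinity to adenosine receptor A1 (Cavia porcellus), read by radioligand binding (a lower number here means a stronger inhibitor, a higher number a weaker inhibitor), compound 1 `CCCn1c(=O)c2nc(C(C)(C)CCC)[nH]c2n(CCC)c1=O` gives 25 nM and compound 2 `CC(C)(C)CNc1ncnc2c1ncn2C1O[C@H](CO)[C@@H](O)[C@H]1O` gives 17 nM; compound 1 carries the higher of the two numbers, yet the pair sits within the scatter, so no order is drawn between them. Compound 3 `CCCn1c(=O)c2nc(-c3cc4ccccc4s3)[nH]c2n(CCC)c1=O` returns only a limit, > 100000 nM, in this assay; the limit of > 100000 nM in this assay, at which 1 of the 3 values shown sits, marks the extent of that limit.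

Compound 4 `CCCn1c(=O)c2nc(C(C)(O)CC)[nH]c2n(CCC)c1=O` is not yet measured. It differs from compound 1 by 1-hydroxy-1-methylpropyl in place of 1,1-dimethylbutyl on an aromatic carbon. Going by the values given here, no measured step bears on this change, so the expectation rests on compound 1 alone at 25 nM, and a moderate weakening, a step of a 4.0-fold higher number from compound 1 to compound 4 (0.60 log units; beyond the scatter), is expected. Compound 4 is estimated at 100 nM, with a range from 25 nM to 400 nM.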

Compound 4, inhibition constant: 240 nM
Compound 4: the middle estimate sits 2.4-fold (0.38 log units) below what was measured; the range from low to high includes it.
By their numbers in this assay, from the lowest: compounds 2 and 1 (each within the scatter of the next); then compound 4. At a limit, above all of these: compound 3.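

Going by these compounds alone, this is the first measured step at this position, on an aromatic carbon of the five-membered ring, and it shows that the number in this assay responds to the side chain there: 1-hydroxy-1-methylpropyl in place of 1,1-dimethylbutyl gives a 9.6-fold higher number from compound 1 to compound 4 (0.98 log units; beyond the scatter) and a value that remains a number rather than a limit. The step combines the added hydroxy group with a change in the chain, and it cannot separate the two. The compounds shown leave open how a methyl ether in place of the hydroxy group, or a longer chain carrying it, would read. Nothing shown bears on the cause of this step.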